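The source may hold more compounds than are shown below. What is called first, only, known or untested is meant among the compounds shown, and "the series" means these compounds.

Notes on the series in an ADME assay on microsomes from liver (Rattus norvegicus) for metabolic stability; a higher number here means that the compound lasts longer, a lower number that the compound disappears faster. Compound 3 `CC(C)C(c1cnc(N)s1)c1ccc(-c2ccc3cccc(F)c3c2)[nH]c1=O` gives 0.0983 h, the lowest of the two numbers recorded. Compound 2 `CC(C)C(c1ccc(-c2ccc3cccc(F)c3c2)[nH]c1=O)N1CCN/C1=N\C#N` gives 0.327 h, so the step is a 3.3-fold lower number from compound 2 to compound 3 (0.52 log units; beyond the scatter). Compound 1 `CC(C)C(Cc1ncc[nH]1)c1ccc(-c2ccc3cccc(F)c3c2)[nH]c1=O` gives only a limit, < 0.0667 h, consistent with the limit of < 0.0667 h in this assay, at which 1 of the 3 values shown sits. Compound 4 `CC(C)C(Cc1nnc[nH]1)c1ccc(-c2ccc3cccc(F)c3c2)[nH]c1=O` differs from compound 3 by (4H-1,2,4-triazol-3-yl)methyl in place of 2-amino-1,3-thiazol-5-yl on a saturated chain carbon bound to an aromatic carbon and a saturated chain carbon. The nearest measured comparison is an at least 1.4-fold higher number from compound 1 to compound 3 (0.16 log units; that floor lies within the scatter), where (1H-imidazol-2-yl)methyl was replaced by 2-amino-1,3-thiazol-5-yl and the floor of the step lay within the scatter. Compound 4 returns to a five-membered azolylmethyl group, so a somewhat lower number than compound 3 is expected, possibly reaching the limit of this assay. The estimate for compound 4 is 0.07 h, range 0.03 h to 0.2 h. That is an expected step of a 1.4-fold lower number from compound 3 to compound 4 (0.15 log units; within the scatter).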

Compound 4, half-life: 0.1 h
The estimate for compound 4 lay 1.4-fold (0.15 log units) below the measured number; measured number inside the range.
By their numbers in this assay, from the lowest: compounds 3 and 4 (each within the scatter of the next); then compound 2. At a limit, below all of these: compound 1.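

In this assay the (4H-1,2,4-triazol-3-yl)methyl group of compound 4 and the 2-amino-1,3-thiazol-5-yl group of compound 3 are not separated (a 1.0-fold higher number from compound 3 to compound 4 (0.01 log units; within the scatter)), and the non-aromatic five-membered ring group keeps its margin over the triazole as well (a 3.3-fold lower number from compound 2 to compound 4 (0.51 log units; beyond the scatter)). 4H-1,2,4-triazol-3-yl in place of 1H-imidazol-2-yl gives only a floor (an at least 1.4-fold higher number from compound 1 to compound 4 (0.17 log units; that floor lies within the scatter)). Compound 1 remains a limit of the assay: the limit of < 0.0667 h in this assay, at which 1 of the 4 values shown sits.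

As far as these compounds go, whether a non-aromatic ring at this place generally gives the higher number stays open with a single such compound, compound 2. A morpholine or a longer chain there would test this.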